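This account rests on a few compounds, and the source may have more. Where it says the series, first, only, none or still open, it means among the compounds named here.

Series values in a functional assay on MDA-MB-231 cells (Homo sapiens) for antiproliferative activity, read by MTT assay, with a stated time of 24 h; on this read-out higher numbers stand for weaker inhibition and lower numbers for stronger inhibition:
- compound 1 `CCCCc1oc2ccccc2c1C(=O)c1ccc(OCC(=O)NCc2ccccc2)cc1`: > 50000 nM, a limit of the assay and not a number
- compound 2 `CCCCc1oc2ccccc2c1C(=O)c1ccc(OCCCC(=O)N2CCCCC2)cc1`: 36000 nM
- compound 3 `CCCCc1oc2ccccc2c1C(=O)c1ccc(OCCCC(=O)N2CCOCC2)cc1`: 31600 nM

For the measured compounds named here, compound 3 and compound 2 hold the only two exact numbers, and these lie within the scatter of each other: a 1.1-fold lower number from compound 2 to compound 3 (0.06 log units; within the scatter). The next change leads to compound 4 `CCCCc1oc2ccccc2c1C(=O)c1ccc(OCCCC(=O)N[C@@H](C)c2ccccc2)cc1`, with (1-phenylethyl)amino in place of morpholin-4-yl on a carbonyl carbon.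

The closest measured change at this carbonyl carbon is a 1.1-fold lower number from compound 2 to compound 3 (0.06 log units; within the scatter), which is small. The steps starting from compound 1 also bear on it, since that compound carries benzylcarbamoyl: an at least 1.3-fold lower number from compound 1 to compound 2 (0.14 log units; that floor lies within the scatter) and an at least 1.5-fold lower number from compound 1 to compound 3 (0.19 log units; that floor lies within the scatter). Both give only floors, and neither shows a change beyond the scatter. Going by the values given here, no measured compound has the new group itself, so the range stays wide and a limit result remains possible. No shift beyond the scatter is therefore expected in this assay, and the expected step is a 1.1-fold lower number from compound 3 to compound 4 (0.02 log units; within the scatter). The estimate for compound 4 is 30000 nM, with an expected range of 12000 nM to 60000 nM.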

Compound 4, half-maximal inhibitory concentration: > 50000 nM
Compound 4 gave a limit, no number (the forecaster's own chance of this, stated with the estimate: 25%); middle value at least 1.6-fold (0.22 log units) from the limit.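

At the carbonyl carbon, (1-phenylethyl)amino in place of morpholin-4-yl gives in this assay an at least 1.5-fold higher number from compound 3 to compound 4 (0.19 log units; that floor lies within the scatter), and in place of piperidin-1-yl it gives an at least 1.3-fold higher number from compound 2 to compound 4 (0.14 log units; that floor lies within the scatter); both floors lie within the scatter, so no shift beyond it can be read. Compound 4 gives > 50000 nM, a limit of the assay and not a number. Unlike morpholin-4-yl and piperidin-1-yl, this group, with its aromatic ring, amide hydrogen and defined stereocentre, yields no exact number here, so the series gains a second result at the ceiling of the read-out: the limit of > 50000 nM in this assay, at which 2 of the 4 values shown sit.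

Going by these compounds, how far the true value of compound 4 lies past the limit stays open, and with it the real size of both steps. Also open, on these data alone, is whether a dimethylamino group or a hydroxyl-bearing piperidine at this carbonyl carbon would give an exact number.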